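Piperidine Addition and Kinetic Solubility in a Fluorinated Analogue

The source may report more compounds than this note shows. Statements on the series, on what has been measured and on what is new or still open speak of the compounds shown alone.

In a physicochemical assay for solubility, read by HPLC, in phosphate buffer, measured as kinetic solubility, with a stated time of 1 h, at pH 7.4, tested at 250 uM (on this read-out higher numbers stand for higher solubility and lower numbers for lower solubility), compound 1 `O=C(NCCCCc1ccccc1)n1cc(-c2ccccc2)oc1=O` gives only a limit of the assay, < 1000 nM. Compound 2 `O=C(NCCCCc1ccccc1)n1cc(-c2ccc(F)cc2)oc1=O` likewise gives only a limit, < 1000 nM. The two cores differ by fluoro in place of hydrogen on an aromatic carbon, and the step between them is a step that the two limits leave unreadable from compound 1 to compound 2. Two of the three measured values sit at a floor: the limit of < 1000 nM in this assay, at which 2 of the 3 values shown sit. Compound 3 `CN1CCC(c2cccc(-c3cn(C(=O)NCCCCc4ccccc4)c(=O)o3)c2)CC1` gives 70000 nM in this assay, so the change 1-methylpiperidin-4-yl in place of hydrogen on an aromatic carbon produced an at least 70-fold higher number from compound 1 to compound 3 (1.84 log units; beyond the scatter). Compound 4 `CN1CCC(c2cc(F)ccc2-c2cn(C(=O)NCCCCc3ccccc3)c(=O)o2)CC1` carries the same kind of change on the core of compound 2, (1-methylpiperidin-4-yl in place of hydrogen on an aromatic carbon); here the entering group sits ortho to a large group and meta to a fluoro group, whereas in compound 3 it sits meta to a large group. The step from compound 2 to compound 4 is estimated at an at least 60-fold higher number from compound 2 to compound 4 (1.77 log units; beyond the scatter) in this assay, resting on the measured step of an at least 70-fold higher number from compound 1 to compound 3 (1.84 log units; beyond the scatter). Compound 4 is expected to reach about 60000 nM, between 15000 nM and 200000 nM.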

Compound 4, solubility: 60000 nM
Beside the measured number, compound 4's estimate shows no gap at the digits printed; low and high end bracket the measured number.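

In this assay, putting 1-methylpiperidin-4-yl on the core of compound 2 gives an at least 60-fold higher number from compound 2 to compound 4 (1.77 log units; beyond the scatter), so the large step seen on the core of compound 1 also appears on a second core, with the entering group ortho to a large group and meta to a fluoro group. This step is only a lower bound, and its true size cannot be read, because it starts from a limit of the assay: the limit of < 1000 nM in this assay, at which 2 of the 4 values shown sit. Two cores are a small sample, so this does not show that the change would carry over to other cores.

Still open, going by these compounds, is whether a different amine, such as morpholine, would give a similar step in the same place. The same question applies to a carboxylic acid.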